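From 4-methoxyphenyl to thiophen-2-yl on a shared core

The source may hold more compounds than are shown below. What is called first, only, known or untested is meant among the compounds shown, and "the series" means these compounds.

Of the compounds shown here, three sharing one core have been measured in a functional assay on KB cells (Homo sapiens) for inhibition, with a stated time of 72 h; on this read-out lower numbers stand for stronger inhibition and higher numbers for weaker inhibition. Compound 1 (`COc1ccc(S(=O)(=O)N2CCc3cccc(-c4cc(OC)c(OC)c(OC)c4)c32)cc1`) gives 3690 nM, compound 3 (`COc1ccc(S(=O)(=O)N2CCc3cccc(-c4c(F)c(F)c(F)c(F)c4F)c32)cc1`) gives 4040 nM, and compound 2 (`COc1ccc(-c2cccc3c2N(S(=O)(=O)c2ccc(OC)cc2)CC3)cc1`) gives 337 nM. Compound 2 therefore holds the lowest number of the three, and the other two lie beyond the scatter from it.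

Compound 4 (`COc1ccc(S(=O)(=O)N2CCc3cccc(-c4cccs4)c32)cc1`) has not yet been measured. It carries thiophen-2-yl in place of 4-methoxyphenyl on an aromatic carbon. Among the compounds with values here, no measured pair differs in one place only, so the expectation rests on the values alone: compound 2 stands at 337 nM, while compound 1 stands at 3690 nM with a different aromatic group on the same carbon. The expected step in this assay is a 3.3-fold higher number from compound 2 to compound 4 (0.51 log units; beyond the scatter), a moderate rise towards weaker inhibition that should lie just beyond the scatter. For compound 4 the estimated value is 1100 nM, with an expected range from 330 nM to 3800 nM.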

Compound 4, half-maximal inhibitory concentration: 215 nM
Beside the measured number, compound 4's estimate is 5.1-fold (0.71 log units) above it, and the stated range ends above it.
By their numbers in this assay, from the lowest: compounds 4 and 2 (each within the scatter of the next); then compounds 1 and 3 (each within the scatter of the next).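

In this assay, replacing 4-methoxyphenyl with thiophen-2-yl gives a 1.6-fold lower number from compound 2 to compound 4 (0.20 log units; within the scatter), so on this aromatic carbon a five-membered aromatic ring with one sulfur atom can take the place of the six-membered aromatic ring without a change beyond the scatter. Until now, only compound 2 had a number far from the others; compound 4 at 215 nM now stands with it, apart from compound 1 at 3690 nM and compound 3 at 4040 nM, so low numbers are not confined to 4-methoxyphenyl on this carbon. Nothing available explains why these two groups read alike.

As far as these compounds go, it remains open whether the sulfur atom matters, which furan-2-yl or thiophen-3-yl on the same carbon could test. From the compounds shown here alone, it is also open whether plain phenyl or a pyridine ring would stay with compound 2 and compound 4.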